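Varying the ring substituent in a TRPV1 antagonist series

This account rests on a few compounds, and the source may have more. Where it says the series, first, only, none or still open, it means among the compounds named here.

Compound 1: `CC(C(=O)NCc1ccc(C(F)(F)F)cc1N1CCC(c2ccc(F)cc2)CC1)c1ccc(NS(C)(=O)=O)c(F)c1`, 0.9 nM
Compound 2: `Cc1ccc(N2CCN(c3cc(C(F)(F)F)ccc3CNC(=O)C(C)c3ccc(NS(C)(=O)=O)c(F)c3)CC2)cc1`, 0.7 nM
Compound 3: `CC(C(=O)NCc1ccc(C(F)(F)F)cc1OC1CCCCC1)c1ccc(NS(C)(=O)=O)c(F)c1`, 0.7 nM

The three measured compounds share one core and differ only in the group carried on an aromatic carbon ortho to a large group and meta to a trifluoromethyl group. In an assay on CHO cells for antagonist activity at transient receptor potential cation channel subfamily V member 1 (Homo sapiens), read by FLIPR (on this read-out higher numbers stand for weaker inhibition and lower numbers for stronger inhibition), compound 1 gives 0.9 nM, compound 2 gives 0.7 nM and compound 3 gives 0.7 nM. Compound 3 stands level with compound 2 at the digits shown, and the two together hold the lowest numbers of the three; the gap between compound 3 and compound 1 lies within the scatter, so no order among the three can be read from these values.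

Compound 4 is `COc1ccc(-c2cc(C(F)(F)F)ccc2CNC(=O)C(C)c2ccc(NS(C)(=O)=O)c(F)c2)cc1OC`. It differs from compound 3 in one place: 3,4-dimethoxyphenyl in place of cyclohexyloxy on an aromatic carbon. Among the compounds with values here, no step between measured compounds has been recorded for this change, so its size is not known from this set. Since three quite different groups at this position all give low numbers in this assay, a small step, if any, is expected for compound 4, a 2.1-fold higher number from compound 3 to compound 4 (0.33 log units; beyond the scatter), leaning toward a slightly higher number. Compound 4 is therefore estimated at 1.5 nM, within a range from 0.4 nM to 6 nM.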

Compound 4, inhibition constant: 8.6 nM
Compound 4: the middle estimate sits 5.7-fold (0.76 log units) below what was measured; the measured number lies above the stated range.
By their numbers in this assay, from the lowest: compounds 2, 3 and 1 (each within the scatter of the next); then compound 4.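

In this assay, the aromatic carbon ortho to a large group and meta to a trifluoromethyl group proves not to accept every group equally: 3,4-dimethoxyphenyl in place of cyclohexyloxy gives a 12-fold higher number from compound 3 to compound 4 (1.09 log units; beyond the scatter). The groups carried by compounds 1, 2 and 3 had left the numbers within the scatter of one another, so this is the first change at this position shown to matter, and compound 4 now stands apart from those three. The change replaces a six-membered non-aromatic ring of carbon only with a six-membered aromatic ring of carbon only and brings one more hydrogen-bond acceptor, but nothing available here gives a reason for the step.

The compounds shown leave open whether the higher number goes with the aromatic ring itself or with its two methoxy groups, a question that a plain phenyl group or a phenyl group with a single methoxy group at this carbon would address. As far as these compounds go, it also remains open how a cyclohexyl group joined directly, without the oxygen, would compare with the cyclohexyloxy group of compound 3.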